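The source may report more compounds than this note shows. Statements on the series, on what has been measured and on what is new or still open speak of the compounds shown alone.

The measured compounds in an ADME assay on HepG2 2.2.15 cells (Homo sapiens) for cytotoxicity (a higher number here means that more compound is tolerated, a lower number that less compound is tolerated), are: compound 1 `Clc1ccc(C(Oc2ccc3cc(Br)ccc3c2)c2cnc(NCC3CCCCC3)s2)cc1`, "not toxic" (no number reported); compound 2 `CCOC(=O)CCCNc1ncc(C(Oc2ccc3cc(Br)ccc3c2)c2ccc(Cl)cc2)s1`, "not toxic" (no number reported); compound 3 `COc1ccc(C(=O)Nc2ncc(C(Oc3ccc4cc(Br)ccc4c3)c3ccc(Cl)cc3)s2)cc1`, > 50000 nM.

Compound 3 stands only at a limit of this assay, > 50000 nM, not at a measured number; that limit is the one described in the limit of > 50000 nM in this assay, at which 1 of the 3 values shown sits, and the other two entries also give no single number. Compound 4 `O=S(=O)(Nc1ncc(C(Oc2ccc3cc(Br)ccc3c2)c2ccc(Cl)cc2)s1)c1ccc(Cl)cc1` differs from compound 3 in one place: (4-chlorophenyl)sulfonyl in place of (4-methoxyphenyl)carbonyl on a nitrogen on an aromatic ring. Going by the values given here, no step between measured compounds is available to size this change. Given compound 3 at its limit > 50000 nM, no step beyond the scatter is expected from compound 3 to compound 4 in this assay, and compound 4 is estimated to remain at or near the limit, at 50000 nM, within 20000 nM to 100000 nM, a step of a number no higher from compound 3 to compound 4 (the limit leaves the size open).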

Compound 4, half-maximal cytotoxic concentration: "not toxic" (no number reported)
For compound 4 the study gives words and no number; there is nothing to compare the estimate with.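

No step can be read between compound 3 and compound 4, since compound 3 stands at a limit and compound 4 carries only words. On these data alone, how much compound these compounds tolerate in this assay stays open.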